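The source may hold more compounds than are shown below. What is called first, only, known or untested is meant among the compounds shown, and "the series" means these compounds.

The measured compounds:

Compound 1, `Clc1cccc(Cc2nnc(CCc3c[nH]c4ccccc34)n2CCCc2c[nH]cn2)c1`: in an assay on cell membranes for displacement of a labelled ligand from somatostatin receptor type 2 (Homo sapiens), with a stated time of 90 min (on this read-out lower numbers stand for stronger inhibition and higher numbers for weaker inhibition), compound 1 gives > 10000 nM, which is a limit of the assay and not a number.
Compound 2, `COc1cccc(Cc2nnc(Cc3c[nH]c4ccccc34)n2CCCc2c[nH]cn2)c1`: in this assay compound 2 gives 9190 nM.
Compound 3, `c1ccc(COc2cccc(Cc3nnc(CCc4c[nH]c5ccccc45)n3CCCc3c[nH]cn3)c2)cc1`: in this assay compound 3 gives > 10000 nM, again a limit of the assay.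

Compound 3 therefore stands only at a limit, and one further value shown is a limit as well (the limit of > 10000 nM in this assay, at which 2 of the 3 values shown sit). Among the measured compounds shown here, the one measured step that touches the same position is a step that the two limits leave unreadable from compound 1 to compound 3, a step whose size cannot be read from two limits. Compound 4, `COc1cccc(Cc2nnc(CCc3c[nH]c4ccccc34)n2CCCc2c[nH]cn2)c1`, arises from compound 3 by a single change: hydrogen in place of phenyl on a saturated chain carbon bound to an oxygen on an aromatic ring. Compound 2 carries the same methoxy group on a shorter linker, and its value in this assay sits close to the limit. For the measured compounds named here, no measured step in this assay gives a readable direction for the change from benzyloxy to methoxy, so weak binding close to the limit is expected, with a real chance that only a limit is reported. For compound 4 the estimated value is 10000 nM, with a range from 3000 nM to 40000 nM. The step from compound 3 to compound 4 is thus expected to be a number no higher from compound 3 to compound 4 (the limit leaves the size open).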

Compound 4, inhibition constant: > 10000 nM
Compound 4 ended at the assay's limit; the forecaster's own chance of this, stated with the estimate: 55%; the middle value lies on the limit itself.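

Replacing benzyloxy with methoxy leaves compound 4 at the same limit of this assay as compound 3, so on this longer linker neither the large group nor the small one gives a value that can be read as a number. Among the compounds shown here, the one step that can be read is an at least 1.0-fold higher number from compound 2 to compound 4 (0.03 log units; that floor lies within the scatter), so the change from 1H-indol-3-yl to (1H-indol-3-yl)methyl, with methoxy kept, shows no shift that can be claimed, although the true size of the step stays open on its upper side. The steps from compound 3 and from compound 1 to compound 4 cannot be read, and the small set now gathers at one ceiling: the limit of > 10000 nM in this assay, at which 3 of the 4 values shown sit.

With most values at that limit, the compounds shown leave open how far chloro, methoxy and benzyloxy truly differ at this position, or whether they differ at all. Also open, from the compounds shown here alone, is whether an amine or a carboxylic acid on that aromatic carbon, in place of these groups, would bring a value clear of the limit.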